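A few compounds are considered here, and "the series" means these few. Any claim that something is new, unique, unknown or untested is made for them only; others in the source may bear on it.

In an ADME assay on NIH3T3 cells (Mus musculus) for cytotoxicity, read by MTT assay, with a stated time of 24 h (on this read-out lower numbers stand for stronger inhibition and higher numbers for weaker inhibition), compound 2, `N#Cc1ccc(-c2cs/c(=N/NC(=O)CSc3ncccn3)n2-c2ccccc2)cc1`, stands only at a limit. In this assay compound 2 gives < 3.9 ug/mL, which is a limit of the assay rather than a number. Compound 1, `Cc1nnc(SCC(=O)N/N=c2/scc(-c3ccc(C#N)cc3)n2-c2ccccc2)s1`, shares that standing: in this assay compound 1 gives < 3.9 ug/mL, again a limit. Compound 3, `N#Cc1ccc(-c2cs/c(=N/NC(=O)CSc3nnnn3-c3ccccc3)n2-c2ccccc2)cc1`, differs from both only in the group on the sulfur, and in this assay compound 3 gives 453 ug/mL. The step of an at least 110-fold higher number from compound 1 to compound 3 (2.06 log units; beyond the scatter) and the step of an at least 110-fold higher number from compound 2 to compound 3 (2.06 log units; beyond the scatter) show that putting 1-phenyl-1H-tetrazol-5-yl on the sulfur moves the number greatly, whereas the step that the two limits leave unreadable from compound 1 to compound 2 cannot be read, since both compounds sit at the limit of < 3.9 ug/mL in this assay, at which 2 of the 3 values shown sit.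

Compound 4, `O=C(CSc1ncccn1)N/N=c1/scc(-c2ccc([N+](=O)[O-])cc2)n1-c1ccccc1`, is the compound still to be measured. Its difference from compound 2 lies elsewhere: nitro in place of cyano on an aromatic carbon. The change sits on an aromatic carbon of a six-membered aromatic ring of carbon only, para to a large group, and the sulfur-linked pyrimidin-2-yl stays in place. Within the data shown here, none of the measured steps touches this position; all of them concern the group on the sulfur. No step beyond the scatter is therefore expected in this assay. Compound 4 is expected to give about 3 ug/mL, between 1 ug/mL and 8 ug/mL, most likely reported once more as a limit. This amounts to an expected step that the limit leaves unreadable from compound 2 to compound 4.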

Compound 4, half-maximal inhibitory concentration: 193 ug/mL
Estimate against measurement, compound 4: 64-fold (1.81 log units) below; measured number outside the range, above it.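

The earlier compounds shown here differed only in the group on the sulfur, so they said nothing about the aromatic carbon para to a large group. This result shows that this position also matters in this assay, where higher numbers stand for weaker inhibition: nitro in place of cyano gives an at least 49-fold higher number from compound 2 to compound 4 (1.69 log units; beyond the scatter), with the sulfur-linked pyrimidin-2-yl unchanged. In this assay compound 2 gives < 3.9 ug/mL, a limit and not a number, and it stands at this mark: the limit of < 3.9 ug/mL in this assay, at which 2 of the 4 values shown sit.

From the compounds shown here alone, only cyano and nitro are seen at this position, so it stays open where an amine, a carboxylic acid or a methoxy group there would fall. It also stays open whether nitro in place of cyano would do the same with 5-methyl-1,3,4-thiadiazol-2-yl or 1-phenyl-1H-tetrazol-5-yl on the sulfur, and the compounds shown give no cause for the step.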